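From methyl to ethynyl on an aromatic carbon

The compounds below may be only part of what the source reports. "The series", "measured", "known", "first", "only" and "open" are said of these compounds alone.

In an ADME assay on microsomes from liver (Homo sapiens) for metabolic stability, read by LC-MS, using NADPH, with a stated time of 10 min, tested at 0.1 uM (a higher number here means faster removal of the compound, a lower number slower removal), compound 2 (`Cc1cccc(N2C(=O)CSC2c2cccc(C(=O)NCCCCc3ccccc3)c2)c1`) gives 2550 mL.min-1.g-1 and compound 1 (`CC1SC(c2cccc(C(=O)NCCCCc3ccccc3)c2)N(c2ccc(C3CC3)cc2)C1=O`) gives 2010 mL.min-1.g-1 as its read-out, so the two numbers lie within the scatter of each other. Compound 3 (`C#Cc1cccc(N2C(=O)CSC2c2cccc(C(=O)NCCCCc3ccccc3)c2)c1`) has not yet been measured. It carries ethynyl in place of methyl on an aromatic carbon, meta to a large group, and ethynyl in place of methyl on an aromatic carbon is its whole difference from compound 2. Within the data shown here, no measured pair isolates a change at this place. Compound 1 at 2010 mL.min-1.g-1 and compound 2 at 2550 mL.min-1.g-1 differ in more than one place and still do not separate, so no step beyond the scatter is expected in this assay here. The expected step of a 1.1-fold lower number from compound 2 to compound 3 (0.04 log units; within the scatter) stays within the scatter. For compound 3 the estimated value is 2300 mL.min-1.g-1 (expected range 1100 mL.min-1.g-1 to 4800 mL.min-1.g-1).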

Compound 3, intrinsic clearance in microsomes: 751 mL.min-1.g-1
Estimate against measurement, compound 3: 3.1-fold (0.49 log units) above, outside the stated range (below it).
By their numbers in this assay, from the lowest: compound 3; then compounds 1 and 2 (each within the scatter of the next).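

Ethynyl in place of methyl on this aromatic carbon, meta to a large group, is the first change at this place that can be read alone, and in this assay it gives a 3.4-fold lower number from compound 2 to compound 3 (0.53 log units; beyond the scatter), a modest step. It shows that this single place on the ring can move the clearance read-out beyond the scatter, and that the triple bond goes with slower removal in this pair. Nothing measured here gives a reason for the step.

As far as these compounds go, what stays open is whether the lower number comes from gaining ethynyl or from losing methyl: a plain hydrogen, a chlorine or a nitrile on this carbon would separate the two. From the compounds shown here alone, whether ethynyl has the same effect with the other substituents of the shared core also remains unknown.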